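Moving the methoxy group on an inactive analogue

A few compounds are considered here, and "the series" means these few. Any claim that something is new, unique, unknown or untested is made for them only; others in the source may bear on it.

For the measured compounds named here, compound 1 `COc1ccc(-c2cn(C/C=C3\OC(=O)C(OCc4ccccc4)=C3OCc3ccccc3)nn2)cc1` is one of three compounds measured in a functional assay on A549 cells (Homo sapiens) for antiproliferative activity, read by MTT assay, with a stated time of 72 h; on this read-out higher numbers stand for weaker inhibition and lower numbers for stronger inhibition. In this assay compound 1 returns only the limit > 100000 nM, not a number, so its place among the values is bounded rather than fixed. Compound 2 `COc1ccc(-c2cn(C[C@H](O)[C@H]3OC(=O)C(OCc4ccccc4)=C3OCc3ccccc3)nn2)cc1`, which carries the same 4-methoxyphenyl on a differently built linker, gives 28300 nM in this assay. Compound 3 `O=C1O[C@H]([C@@H](O)Cn2cc(CCO)nn2)C(OCc2ccccc2)=C1OCc1ccccc1` in this assay reaches only the limit > 100000 nM. Going by the values given here, the single measured step, an at least 3.5-fold higher number from compound 2 to compound 3 (0.54 log units; beyond the scatter), replaces the aryl group by a short chain, so it speaks to removal of the aryl rather than to where its methoxy sits. Compound 4 `COc1ccccc1-c1cn(C/C=C2\OC(=O)C(OCc3ccccc3)=C2OCc2ccccc2)nn1` differs from compound 1 by 2-methoxyphenyl in place of 4-methoxyphenyl on an aromatic carbon. Among the compounds with values here, no measured step addresses a change of this kind, and the reference itself is a limit, a situation shared with compound 3 as the limit of > 100000 nM in this assay, at which 2 of the 3 values shown sit, records, so no numerical anchor exists for the move. The expectation is therefore a step no larger than the scatter, a number no higher from compound 1 to compound 4 (the limit leaves the size open). Compound 4 is estimated at 100000 nM in this assay. Its expected range runs from 30000 nM to 300000 nM, and a limit rather than a number is the likelier outcome for compound 4.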

Compound 4, half-maximal inhibitory concentration: > 100000 nM
Compound 4: no number, only a limit; the forecaster's own chance of this, stated with the estimate: 75%; the middle value lies on the limit itself.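

In this assay compound 4 returns > 100000 nM, which is a limit and not a number. For the compounds shown here, compound 1 also returns a limit, so no step between compound 1 and compound 4 can be read, and the result joins the most common entry: the limit of > 100000 nM in this assay, at which 3 of the 4 values shown sit. The compounds shown leave open whether 2-methoxyphenyl in place of 4-methoxyphenyl changes the antiproliferative activity at all.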